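Chloro for iodo: expectation for compound 4

This account rests on a few compounds, and the source may have more. Where it says the series, first, only, none or still open, it means among the compounds named here.

Compound 3 `CCCc1cc(N)c2cc(NC(=O)/C=C/c3ccc(I)cc3)ccc2n1` gives 2.3 nM in an assay on isolated protein for displacement of a labelled ligand from melanin-concentrating hormone receptor 1 (Homo sapiens) (on this read-out lower numbers stand for stronger inhibition and higher numbers for weaker inhibition), the lowest of the three numbers recorded. Compound 1 `CCCc1cc(N)c2cc(NC(=O)/C=C/c3ccc(F)cc3)ccc2n1` gives 130 nM and compound 2 `CCCc1cc(N)c2cc(NC(=O)/C=C/c3ccc(O)cc3)ccc2n1` gives 1100 nM; the steps are a 57-fold lower number from compound 1 to compound 3 (1.75 log units; beyond the scatter) and a 480-fold lower number from compound 2 to compound 3 (2.68 log units; beyond the scatter), with an 8.5-fold higher number from compound 1 to compound 2 (0.93 log units; beyond the scatter) between those two. Compound 4 `CCCc1cc(N)c2cc(NC(=O)/C=C/c3ccc(Cl)cc3)ccc2n1` differs from compound 3 by chloro in place of iodo on an aromatic carbon, sitting on an aromatic carbon of a six-membered aromatic ring of carbon only, para to a large group. Among the compounds with values here, the step that bears on it is a 57-fold lower number from compound 1 to compound 3 (1.75 log units; beyond the scatter), the span between the two halogens measured so far; no chloro analogue is measured, so the estimate is placed between the fluoro and iodo numbers, a higher number than compound 3 by less than that span. Compound 4 is therefore expected to show an 8.7-fold higher number from compound 3 to compound 4 (0.94 log units; beyond the scatter), an estimate of 20 nM with a range of 5 nM to 80 nM.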

Compound 4, half-maximal inhibitory concentration: 6 nM
Estimate against measurement, compound 4: 3.3-fold (0.52 log units) above; measured number inside the range.
By their numbers in this assay, from the lowest: compound 3; then compound 4; then compound 1; then compound 2.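

Chloro in place of iodo at this position gives up little in this assay: the change is a 2.6-fold higher number from compound 3 to compound 4 (0.42 log units; beyond the scatter), against a 22-fold lower number from compound 1 to compound 4 (1.34 log units; beyond the scatter) and a 180-fold lower number from compound 2 to compound 4 (2.26 log units; beyond the scatter), so chloro stands much nearer to iodo than to fluoro or hydroxy. Among the three halogens, the numbers are therefore unevenly spaced, with the wide gap on the fluoro side. Nothing at hand accounts for this order.

Open, going by these compounds, is where bromo falls relative to chloro and iodo. Also open, on these data alone, is whether methyl, trifluoromethyl or methoxy at this position would track the halogens or hydroxy.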